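Trimming a Trifluoromethyl to Fluoro on a Potent Core

The source may hold more compounds than are shown below. What is called first, only, known or untested is meant among the compounds shown, and "the series" means these compounds.

Of the compounds shown here, three have been tested in a functional assay on CHO cells for antagonist activity at transient receptor potential cation channel subfamily V member 1 (Homo sapiens), read by FLIPR; on this read-out lower numbers stand for stronger inhibition and higher numbers for weaker inhibition. Compound 1 `Cc1cccnc1-c1ccc(NC(=O)c2ccc(C(F)(F)F)cc2)cc1` gives 160 nM, compound 2 `CC(C)(C)c1ccc(C(=O)Nc2ccc(-c3ncccc3C(F)(F)F)cc2)cc1` gives 470 nM, and compound 3 `FC(F)(F)c1ccc(-c2nc3cc(-c4ncccc4C(F)(F)F)ccc3[nH]2)cc1` gives 22 nM, the lowest number of the three and separated from both others by more than the usual scatter, so compound 3 is the most potent of the set. Compound 4 `Fc1ccc(-c2nc3cc(-c4ncccc4C(F)(F)F)ccc3[nH]2)cc1` keeps the core of compound 3 and differs in a single change: fluoro in place of trifluoromethyl on an aromatic carbon, sitting on an aromatic carbon of a six-membered aromatic ring of carbon only, para to a large group. Within the data shown here, no measured pair shows this exact change, so the size of the step is uncertain. A modest weakening is expected, a 2.7-fold higher number from compound 3 to compound 4 (0.44 log units; beyond the scatter), though a step within the scatter cannot be ruled out. Compound 4 is therefore estimated at 60 nM in this assay, within a range from 20 nM to 200 nM.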

Compound 4, half-maximal inhibitory concentration: 320 nM
Estimate against measurement, compound 4: 5.3-fold (0.73 log units) below; the measured number lies above the stated range.
By their numbers in this assay, from the lowest: compound 3; then compounds 1, 4 and 2 (each within the scatter of the next, the first and the last beyond it).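

At this position, on a six-membered aromatic ring of carbon only and para to a large group, the group present matters greatly. Fluoro in place of trifluoromethyl gives a 15-fold higher number from compound 3 to compound 4 (1.16 log units; beyond the scatter) in this assay and is the only single-place change in the set, so it shows that most of the potency of compound 3 depends on keeping trifluoromethyl here. Nothing measured here explains why the step is so large.

From the compounds shown here alone, how chloro, methoxy or nitrile at this position would compare with trifluoromethyl remains open. So does whether the same change would have a similar effect on a different core.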